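Methyl on the ring amine nitrogen: compound 3 to compound 4

A few compounds are considered here, and "the series" means these few. Any claim that something is new, unique, unknown or untested is made for them only; others in the source may bear on it.

Compound 3 `COc1ccc2c(c1)c(S(=O)(=O)c1cccc(F)c1)cn2C1CCCNC1` in an assay on HeLa cells for displacement of a labelled ligand from 5-hydroxytryptamine receptor 6 (Homo sapiens), with a stated time of 2 h (on this read-out higher numbers stand for weaker inhibition and lower numbers for stronger inhibition), gives 10.7 nM, the highest of the three numbers measured. Compound 2 `O=S(=O)(c1cccc(F)c1)c1cn(C2CCCNC2)c2ccccc12` gives 6 nM, and a 1.8-fold higher number from compound 2 to compound 3 (0.25 log units; within the scatter). Compound 1 `CN1CCC(n2cc(S(=O)(=O)c3cccc4cccnc34)c3ccccc32)C1` gives 2.8 nM, a gap from compound 3 that lies beyond the scatter, but no single change connects the two. Compound 4 `COc1ccc2c(c1)c(S(=O)(=O)c1cccc(F)c1)cn2C1CCCN(C)C1` differs from compound 3 by methyl in place of hydrogen on an amine nitrogen in a ring. For the measured compounds named here, no measured step alters the amine nitrogen alone; the one step available concerns the methoxy and stays within the scatter. Compound 1 carries a methyl on its ring amine yet differs from compound 3 in several other places, so it is no clean reference. For compound 4 a step of a 1.3-fold lower number from compound 3 to compound 4 (0.13 log units; within the scatter) is therefore expected, within the scatter. Compound 4 is estimated at 8 nM in this assay, with a range of 3 nM to 25 nM.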

Compound 4, inhibition constant: 68 nM
Estimate against measurement, compound 4: 8.5-fold (0.93 log units) below; the whole stated range lies below it.
By their numbers in this assay, from the lowest: compound 1; then compounds 2 and 3 (each within the scatter of the next); then compound 4.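

For the compounds shown here, on the amine nitrogen of the piperidin-3-yl group, the hydrogen matters in this assay: methyl in its place gives a 6.4-fold higher number from compound 3 to compound 4 (0.80 log units; beyond the scatter), the only step that lies beyond the scatter. Going by these compounds alone, compound 1 also carries a methyl on its ring amine, but it differs in several other places, so this step is the only clean reading of the change. Nothing measured here accounts for the step.

From the compounds shown here alone, whether the step holds on the core of compound 2, without the methoxy, remains open. So does the reading for an ethyl group or a longer chain on this nitrogen.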